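A few compounds are considered here, and "the series" means these few. Any claim that something is new, unique, unknown or untested is made for them only; others in the source may bear on it.

Measured compounds:
compound 1, `CC(C)(C)OC(=O)N1CCC(O[C@H]2CC[C@H](Oc3ccc(S(C)(=O)=O)cc3)CC2)CC1` — 16.1 nM
compound 2, `CC(C)(C)OC(=O)N1CCC(O[C@H]2CC[C@H](Oc3ccc(S(C)(=O)=O)cc3F)CC2)CC1` — 8.5 nM
compound 3, `CC(C)(C)OC(=O)N1CCC(O[C@H]2CC[C@H](Oc3ccc(S(C)(=O)=O)c(F)c3)CC2)CC1` — 52 nM

All three numbers come from a functional assay on isolated protein for agonist activity at Glucose-dependent insulinotropic receptor (Homo sapiens), read by HTRF and cAMP accumulation; on this read-out lower numbers stand for an effect already at smaller amounts and higher numbers for an effect only at larger amounts of compound. Compound 1 sits between the other two: a 3.2-fold higher number from compound 1 to compound 3 (0.51 log units; beyond the scatter) is a step beyond the scatter, whereas a 1.9-fold lower number from compound 1 to compound 2 (0.28 log units; within the scatter) stays within it, so compound 1 and compound 2 cannot be told apart on these numbers.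

Compound 4, `CC(C)(C)OC(=O)N1CCC(O[C@H]2CC[C@H](Oc3ccc(S(C)(=O)=O)cn3)CC2)CC1`, has not yet been measured in this assay. It differs from compound 1 in one place: 5-(methylsulfonyl)pyridin-2-yl in place of 4-(methylsulfonyl)phenyl on an oxygen on a saturated carbon. Neither measured step is the same kind of change. Both swap a hydrogen for a fluoro on the aromatic ring that is now being replaced, and they point in opposite directions, one within the scatter and one modestly beyond it. That leaves no measured guide for exchanging a ring carbon for a ring nitrogen, so the expectation is a step of no more than modest size in either direction, most likely none beyond the scatter.

Compound 4 is therefore expected to give about 20 nM in this assay, with a range from 6 nM to 65 nM. The step this estimate implies is a 1.2-fold higher number from compound 1 to compound 4 (0.09 log units; within the scatter).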

Compound 4, half-maximal effective concentration: 47 nM
Compound 4: middle estimate off by 2.4-fold (0.37 log units), on the low side, within the range that was stated.
By their numbers in this assay, from the lowest: compounds 2 and 1 (each within the scatter of the next); then compounds 4 and 3 (each within the scatter of the next).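

In this assay the exchange of 4-(methylsulfonyl)phenyl for 5-(methylsulfonyl)pyridin-2-yl gives a 2.9-fold higher number from compound 1 to compound 4 (0.47 log units; beyond the scatter) and so moves the number beyond the scatter. The earlier compounds shown here showed this place responding to a fluoro on the aromatic ring; compound 4 shows that a ring nitrogen in place of a ring carbon also counts here, even though the group keeps its 10 heavy atoms and its methylsulfonyl. Nothing measured here accounts for this step.

Still open, going by these compounds, is whether a fluoro on the 5-(methylsulfonyl)pyridin-2-yl group would shift the number as it did on the 4-(methylsulfonyl)phenyl group. Also open, on these data alone, is what happens when a nitrile or a carboxylic acid takes the place of the methylsulfonyl on either ring.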